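Trifluoromethyl in place of isopropyl on the shared core

The compounds below may be only part of what the source reports. "The series", "measured", "known", "first", "only" and "open" are said of these compounds alone.

In a functional assay on A549 cells (Homo sapiens) for inhibition, read by colorimetric assay and MTT assay, with a stated time of 72 h (on this read-out lower numbers stand for stronger inhibition and higher numbers for weaker inhibition), compound 1 (`CCCCCCOc1ncc(-c2ccccc2OC)n1C`) gives 37000 nM and compound 2 (`C=CCCCCOc1ncc(-c2cc(C(C)C)ccc2OC)n1C`) gives 4000 nM as the lower of the two numbers, a gap beyond the scatter. These two compounds differ in more than one place, so their gap cannot be tied to any single change. Compound 3 (`C=CCCCCOc1ncc(-c2cc(C(F)(F)F)ccc2OC)n1C`) carries trifluoromethyl in place of isopropyl on an aromatic carbon para to a methoxy group, and otherwise matches compound 2. Among the measured compounds shown here, no measured pair shows this exchange, so the expectation rests on the structural change alone. Expected in this assay is a small weakening, with a 1.5-fold higher number from compound 2 to compound 3 (0.18 log units; within the scatter) as the estimate and no move clearly beyond the scatter. The expected value for compound 3 is 6000 nM within an estimated range of 2500 nM to 15000 nM on this read-out.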

Compound 3, half-maximal inhibitory concentration: 62000 nM
For compound 3 the middle estimate is 10-fold (1.01 log units) below the measured one; the whole stated range lies below it.
By their numbers in this assay, from the lowest: compound 2; then compounds 1 and 3 (each within the scatter of the next).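

In this assay there is a 16-fold higher number from compound 2 to compound 3 (1.19 log units; beyond the scatter) when trifluoromethyl takes the place of isopropyl para to a methoxy group, so this position is not indifferent to the group it carries. Among the compounds shown here, this is the first step in which a gap beyond the scatter can be tied to a single change, and with the rest of the structure held constant, isopropyl goes with the lower number. Nothing measured here accounts for the size of this step.

The compounds shown leave open whether another group on this carbon, such as an amine or a tert-butyl group, would give a number as low as that of compound 2. They also leave open whether the step would keep its size with a longer chain on the ether oxygen shared by compound 2 and compound 3.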